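Alkyne Side Chains on a Shared Nucleoside Core

The source may report more compounds than this note shows. Statements on the series, on what has been measured and on what is new or still open speak of the compounds shown alone.

Measured so far:
compound 1, `NC(=O)c1ncn(C2O[C@H](CO)[C@@H](O)[C@H]2O)c1C#CCCO`, 1.28 ug/mL
compound 2, `CCCCC#Cc1c(C(N)=O)ncn1C1O[C@H](CO)[C@@H](O)[C@H]1O`, 2.29 ug/mL

Both compounds were tested in a functional assay on L1210 cells (Mus musculus) for inhibition; on this read-out lower numbers stand for stronger inhibition and higher numbers for weaker inhibition. Compound 2 has the highest of the two numbers, and its nearest neighbour is compound 1, though the step of a 1.8-fold higher number from compound 1 to compound 2 (0.25 log units; within the scatter) lies within the scatter, so the two cannot be ranked against each other.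

Compound 3, `CC(C)(O)C#Cc1c(C(N)=O)ncn1C1O[C@H](CO)[C@@H](O)[C@H]1O`, has not yet been measured. It differs from compound 2 in one place: 1-hydroxy-1-methylethyl in place of butyl on a triple-bonded carbon. Cut one bond further out, the change reads hex-1-yn-1-yl to 3-hydroxy-3-methylbut-1-yn-1-yl. A hydroxy group thus returns to the side chain, with two methyl groups alongside it.

For the measured compounds named here, the only measured step that bears on this is the one from compound 1 to compound 2, which swapped a hydroxy for an ethyl on the chain and stayed within the scatter. Compound 3 is therefore expected to land close to compound 2, with the step of a 1.3-fold lower number from compound 2 to compound 3 (0.13 log units; within the scatter) expected to be a slight lowering at most, not beyond the scatter. The estimate for compound 3 in this assay is 1.7 ug/mL, within 0.6 ug/mL to 4.8 ug/mL.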

Compound 3, half-maximal inhibitory concentration: 4.8 ug/mL
Compound 3: the middle estimate sits 2.8-fold (0.45 log units) below what was measured, and the stated range covers the measured number.
By their numbers in this assay, from the lowest: compounds 1 and 2 (each within the scatter of the next); then compound 3.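

In this assay, the group on the triple-bonded carbon now gives a step beyond the scatter, which the first two compounds could not show: replacing butyl with 1-hydroxy-1-methylethyl gives a 2.1-fold higher number from compound 2 to compound 3 (0.32 log units; beyond the scatter), so this position is not indifferent to what it carries. Carrying a hydroxy group does not by itself settle the outcome, since the two side chains with a hydroxy group, 2-hydroxyethyl and 1-hydroxy-1-methylethyl, are also separated by a step beyond the scatter, with a 3.8-fold higher number from compound 1 to compound 3 (0.57 log units; beyond the scatter), while 2-hydroxyethyl and butyl stay within the scatter of each other. No measurement here offers an explanation for either step.

The compounds shown do not separate the two parts of the latest change, the hydroxy group and the two methyl groups on the same carbon, and a tert-butyl group on the triple-bonded carbon would carry the methyl groups without the hydroxy. On these data alone, how an amine or a carboxylic acid at the end of the chain, or a longer chain ending in hydroxy, would compare also remains open.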